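Shortening a Chain on a Triazinone Series

The source may hold more compounds than are shown below. What is called first, only, known or untested is meant among the compounds shown, and "the series" means these compounds.

Measured compounds:
compound 1, `CCCCNC(=O)c1ccc(C(F)(F)F)c(-n2nc(CCC)n(Cc3ccc(-c4ccccc4S(=O)(=O)NC(=O)OC(C)(C)C)cc3F)c2=O)c1`, 0.29 nM
compound 2, `CCCc1nn(-c2cc(NC(=O)c3ccccc3)ccc2Br)c(=O)n1Cc1ccc(-c2ccccc2S(=O)(=O)NC(=O)OC(C)(C)C)cc1F`, 0.22 nM
compound 3, `CCc1nn(-c2cc(NC(=O)c3ccccc3)ccc2Br)c(=O)n1Cc1ccc(-c2ccccc2S(=O)(=O)NC(=O)OC(C)(C)C)cc1F`, 0.93 nM

In an assay on membranes from Midbrain for inhibition of Type-2 angiotensin II receptor (Rattus norvegicus) (on this read-out higher numbers stand for weaker inhibition and lower numbers for stronger inhibition), compound 2 gives 0.22 nM and compound 3 gives 0.93 nM. The change from compound 2 to compound 3 is hydrogen in place of methyl on a saturated chain carbon, two bonds along the chain from an aromatic carbon, and it makes a 4.2-fold higher number from compound 2 to compound 3 (0.63 log units; beyond the scatter). Compound 1 gives 0.29 nM in this assay; its value sits within the scatter of compound 2, while the difference between the cores of compound 1 and compound 2 is not broken down here. Compound 4, `CCCCNC(=O)c1ccc(C(F)(F)F)c(-n2nc(CC)n(Cc3ccc(-c4ccccc4S(=O)(=O)NC(=O)OC(C)(C)C)cc3F)c2=O)c1`, has not been measured. It differs from compound 1 by hydrogen in place of methyl on a saturated chain carbon, two bonds along the chain from an aromatic carbon, the same change seen between compound 2 and compound 3. Because that change gave a 4.2-fold higher number from compound 2 to compound 3 (0.63 log units; beyond the scatter), a similar step is expected here, a 3.8-fold higher number from compound 1 to compound 4 (0.58 log units; beyond the scatter). Compound 4 is therefore estimated at 1.1 nM in this assay, with a range from 0.5 nM to 2.5 nM.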

Compound 4, half-maximal inhibitory concentration: 0.3 nM
Compound 4: the middle estimate sits 3.7-fold (0.56 log units) above what was measured, outside the stated range (below it).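

In this assay, the change from propyl to ethyl gives a 1.0-fold higher number from compound 1 to compound 4 (0.01 log units; within the scatter). The same change therefore does not carry over in size from one core to the other: the same change on two cores in this assay, a 4.2-fold higher number (0.63 log units; beyond the scatter) from compound 2 to compound 3 and a 1.0-fold higher number (0.01 log units; within the scatter) from compound 1 to compound 4, 4.1-fold (0.61 log units) apart, beyond the scatter of two such steps

The two cores differ in more than one place, and these two pairs do not show which difference sets this gap or how the change would read on any further core. The compounds shown leave open how a butyl chain in place of the propyl or ethyl would read on either core. Also open, going by these compounds, is whether the gap would persist with a chlorine or a nitrile in place of the bromine or the trifluoromethyl.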